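From Nitrophenyl to Trimethoxyphenyl: Estimating Compound 3

The compounds below may be only part of what the source reports. "The series", "measured", "known", "first", "only" and "open" are said of these compounds alone.

Compound 1 `COc1ccc(/C=C2\SC(=O)N(CCNC(=O)Nc3c(C)n(C)n(-c4ccccc4)c3=O)C2=O)cc1`: 517 nM
Compound 2 `Cc1c(NC(=O)NCCN2C(=O)S/C(=C\c3ccc([N+](=O)[O-])cc3)C2=O)c(=O)n(-c2ccccc2)n1C`: 245 nM

Within the data shown here, in an assay on isolated protein for inhibition of histone deacetylase 8 (Homo sapiens), read by ELISA (on this read-out lower numbers stand for stronger inhibition and higher numbers for weaker inhibition), compound 2 gives the lower of the two numbers measured so far. Among the measured compounds shown here, the single measured step, a 2.1-fold lower number from compound 1 to compound 2 (0.32 log units; beyond the scatter), separates the pair. Compound 3 `COc1cc(/C=C2\SC(=O)N(CCNC(=O)Nc3c(C)n(C)n(-c4ccccc4)c3=O)C2=O)cc(OC)c1OC` carries 3,4,5-trimethoxyphenyl in place of 4-nitrophenyl on a double-bonded chain carbon bound to a double-bonded ring carbon. That measured step bears on this change only in part: it runs from methoxy to nitro, and the new compound returns to methoxy groups while adding two more. A return toward the higher number is therefore expected, with a 2.0-fold higher number from compound 2 to compound 3 (0.31 log units; beyond the scatter) as the estimated step. Compound 3 is expected to give 500 nM in this assay, within a range from 200 nM to 1300 nM.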

Compound 3, half-maximal inhibitory concentration: 344 nM
Beside the measured number, compound 3's estimate is 1.5-fold (0.16 log units) above it, and the stated range covers the measured number.
By their numbers in this assay, from the lowest: compounds 2, 3 and 1 (each within the scatter of the next, the first and the last beyond it).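

In this assay, the 3,4,5-trimethoxyphenyl group, with 12 heavy atoms against 9 in 4-nitrophenyl, stays within the scatter of both earlier compounds (a 1.4-fold higher number from compound 2 to compound 3 (0.15 log units; within the scatter); a 1.5-fold lower number from compound 1 to compound 3 (0.18 log units; within the scatter)). This place on a double-bonded chain carbon bound to a double-bonded ring carbon therefore accepts the larger group without a step beyond the scatter, although compound 1 and compound 2 remain separated beyond it. No evidence is available to explain this result.

The compounds shown leave open whether a 4-aminophenyl or 4-carboxyphenyl group at this place would give a step beyond the scatter.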